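Sulfonamide variation in one series: tracheal response

The source may report more compounds than this note shows. Statements on the series, on what has been measured and on what is new or still open speak of the compounds shown alone.

Measured compounds:
compound 1, `CNS(=O)(=O)c1ccc2c(c1)C(n1ccccc1=O)=CC(C)(C)O2`, 83%
compound 2, `CC(C)NS(=O)(=O)c1ccc2c(c1)C(n1ccccc1=O)=CC(C)(C)O2`, 94.8%
compound 3, `CN(C)S(=O)(=O)c1ccc2c(c1)C(n1ccccc1=O)=CC(C)(C)O2`, 74.1%

In a functional assay on the whole organism (trachea) with Rattus norvegicus as the target (a lower number here means a smaller maximal response, a higher number a larger maximal response), compound 1 stands second highest of the three numbers. Compound 3 sits nearest to it, the step of a number 8.9 percentage points lower from compound 1 to compound 3 (within the scatter) staying within the scatter; compound 2 lies furthest, with a number 11.8 percentage points higher from compound 1 to compound 2 (beyond the scatter) beyond it.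

Compound 4, `CC1(C)C=C(n2ccccc2=O)c2cc(S(=O)(=O)N3CCOCC3)ccc2O1`, has not been measured. It differs from compound 1 in one place: morpholin-4-yl in place of methylamino on a sulfonyl sulfur. The change both removes the hydrogen on the sulfonamide nitrogen and enlarges the group there, so two measured steps bear on it. Methyl in place of hydrogen on a sulfonamide nitrogen gave a number 8.9 percentage points lower from compound 1 to compound 3 (within the scatter), within the scatter. Isopropyl in place of methyl gave a number 11.8 percentage points higher from compound 1 to compound 2 (beyond the scatter), a modest rise; the exchange a number 20.7 percentage points lower from compound 2 to compound 3 (beyond the scatter) shows that the compound with two methyls on that nitrogen gives the lower of those two numbers. Size of the group alone therefore does not fix the direction, and for morpholin-4-yl, which like the group in compound 3 carries no hydrogen-bond donor, a small drop or no change beyond the scatter is expected. The expected step is a number 6 percentage points lower from compound 1 to compound 4 (within the scatter). Compound 4 is estimated at 77%, between 60% and 94%.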

Compound 4, largest response reached (Emax), in percent of the reference or control that the assay uses: 85.1%
For compound 4 the middle estimate is 8.1 percentage points below the measured one; the range from low to high includes it.
By their numbers in this assay, from the lowest: compounds 3, 1, 4 and 2 (each within the scatter of the next, the first and the last beyond it).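

In this assay, morpholin-4-yl on the sulfonyl sulfur does not separate this compound from the two compounds with a hydrogen on the sulfonamide nitrogen: a number 2.1 percentage points higher from compound 1 to compound 4 (within the scatter) and a number 9.7 percentage points lower from compound 2 to compound 4 (within the scatter) both stay within the scatter. The absence of a hydrogen-bond donor on that nitrogen therefore does not tie these compounds to one level, since compound 3 and compound 4 both lack it, yet a number 11 percentage points higher from compound 3 to compound 4 (beyond the scatter) and this step is the only one of the three to pass beyond the scatter. Nothing available explains why morpholin-4-yl and dimethylamino part in this way.

On these data alone, it remains open whether the ring or its oxygen goes with the number seen for compound 4, a question that piperidin-1-yl or piperazin-1-yl on the sulfonyl sulfur would address. Also open, as far as these compounds go, is how the plain amino group on the sulfur, with no carbon substituent, would compare with methylamino in compound 1 and isopropylamino in compound 2.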